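This account rests on a few compounds, and the source may have more. Where it says the series, first, only, none or still open, it means among the compounds named here.

Working notes on the series.

Of the compounds shown here, two have been measured. Compound 1 `N#CC1=C(N)Oc2c(N)cc3nc4ccccc4nc3c2C12C(=O)N(Cc1cnnn1-c1ccccc1Cl)c1ccccc12` gives 34400 nM in a functional assay on MCF7 cells (Homo sapiens) for antiproliferative activity, read by MTT assay, with a stated time of 48 h; on this read-out higher numbers stand for weaker inhibition and lower numbers for stronger inhibition. Compound 2 `COc1ccccc1-n1nncc1CN1C(=O)C2(C(C#N)=C(N)Oc3c(N)cc4nc5ccccc5nc4c32)c2ccccc21` gives 28900 nM in this assay. For the measured compounds named here, the single measured step, a 1.2-fold lower number from compound 1 to compound 2 (0.08 log units; within the scatter), consists of a methoxy in place of chloro on an aromatic carbon. Compound 2 holds the lowest of the two numbers, with compound 1 as its nearest neighbour, but since the gap lies within the scatter no order between the two is claimed.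

Compound 3 `Cc1ccc(C)c(-n2nncc2CN2C(=O)C3(C(C#N)=C(N)Oc4c(N)cc5nc6ccccc6nc5c43)c3ccccc32)c1` has not yet been measured in this assay. It differs from compound 2 in one place: 2,5-dimethylphenyl in place of 2-methoxyphenyl on an aromatic nitrogen. Going by the values given here, the only measured step that bears on this change is a 1.2-fold lower number from compound 1 to compound 2 (0.08 log units; within the scatter), which also exchanged one small group on an aromatic carbon and produced no shift beyond the scatter. On that basis the exchange of 2-methoxyphenyl for 2,5-dimethylphenyl is expected to leave the number essentially where compound 2 sits, with the expected step of a 1.0-fold higher number from compound 2 to compound 3 (0.02 log units; within the scatter) not exceeding the scatter in either direction. For compound 3 the estimate is 30000 nM, with a range from 12000 nM to 75000 nM.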

Compound 3, half-maximal inhibitory concentration: > 50000 nM
Compound 3: only a limit was reported; the forecaster's own chance of this, stated with the estimate: 10%; middle value at least 1.6-fold (0.22 log units) from the limit.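

In this assay, for the compounds shown here, compound 3 is the first compound with a group changed on this aromatic nitrogen to give a limit and not a number: the limit of > 50000 nM in this assay, at which 1 of the 3 values shown sits. Against its two neighbours the result reads as an at least 1.7-fold higher number from compound 2 to compound 3 (0.23 log units; that floor lies within the scatter) and an at least 1.4-fold higher number from compound 1 to compound 3 (0.16 log units; that floor lies within the scatter); both are floors that lie within the scatter, so no shift beyond the scatter is established, and neither step has an upper bound. Going by these compounds alone, the earlier pair gave two numbers within the scatter of each other, whereas this change, in which 2,5-dimethylphenyl with no hydrogen-bond acceptor enters for 2-methoxyphenyl with one, is the first at this position whose step has no known size.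

The compounds shown do not separate the loss of the methoxy group from the gain of the two methyl groups, since both occur in the one exchange, and the true number for compound 3 remains unknown. Also open, on these data alone, is how an unsubstituted phenyl, or a phenyl bearing an amine or a carboxylic acid, would read on this nitrogen with the shared core unchanged.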